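The source may hold more compounds than are shown below. What is called first, only, known or untested is meant among the compounds shown, and "the series" means these compounds.

Working notes on the thiourea series in an assay on membranes from brain for binding affinity to Lysophosphatidylserine lipase ABHD12 (Mus musculus), read by fluorescence, with a stated time of 20 min; a lower number here means a stronger inhibitor, a higher number a weaker inhibitor.

Of the compounds shown here, three carry numbers so far. Compound 1 `FC(F)(F)Oc1ccc(Oc2ccnc(N3CCC[C@@H](NC(=S)Nc4cccnc4)C3)c2Cl)c(Cl)c1` gives 100000 nM. Compound 2 `S=C(Nc1cccnc1)NC1CCN(c2cc(Cl)ccn2)CC1` gives 2100 nM. Compound 3 `FC(F)(F)Oc1ccc(Oc2ccnc(N3CCC(NC(=S)Nc4cccnc4)CC3)c2C(F)(F)F)cc1` gives 2800 nM. Compound 2 holds the lowest of the three numbers; its nearest neighbour is compound 3, whose number lies within the scatter of that of compound 2, so no order between these two can be read from the data. Going by the values given here, compound 1 sits far beyond the scatter on the weak side, and nothing more than that pair of values can be said of it here, since no single-site step connects it to compound 2.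

The next compound, compound 4 `S=C(Nc1cccnc1)NC1CCN(c2cc(Oc3ccccc3)ccn2)CC1`, has not been measured. Relative to compound 2 it shows (phenoxy in place of chloro on an aromatic carbon); the change sits on an aromatic carbon of a six-membered aromatic ring with one nitrogen, meta to a large group and opposite the ring nitrogen. Among the compounds with values here, no measured pair in the set isolates this change, so no reference step is available. Like the phenoxy of compound 4, compound 3 carries an aryloxy group on the same ring position but differs elsewhere; compound 3 gives 2800 nM, a number within scatter of compound 2.

On that basis the step from compound 2 to compound 4 is expected to be small, with no clear direction beyond the scatter, a 1.2-fold higher number from compound 2 to compound 4 (0.08 log units; within the scatter). Compound 4 is estimated at 2500 nM, with a range from 800 nM to 8000 nM.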

Compound 4, half-maximal inhibitory concentration: 1900 nM
For compound 4 the middle estimate is 1.3-fold (0.12 log units) above the measured one; the measured number falls inside the stated range.
By their numbers in this assay, from the lowest: compounds 4, 2 and 3 (each within the scatter of the next); then compound 1.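

In this assay, going by these compounds alone, the exchange of chloro for phenoxy on the aromatic carbon opposite the ring nitrogen gives a 1.1-fold lower number from compound 2 to compound 4 (0.04 log units; within the scatter) as the first step that isolates a single place. Within the data shown here, the position therefore accepts phenoxy, with its seven heavy atoms, its six-membered aromatic ring of carbon only and its hydrogen-bond acceptor, in place of a lone chlorine without a change that can be told from the scatter, something the earlier compounds could not show, as they differ from compound 2 in more than one place. Nothing measured here offers an explanation for this step.

The compounds shown leave open whether this tolerance extends beyond chloro and phenoxy, for instance to an amine, a carboxylic acid or a longer alkoxy chain on the same carbon. Among these compounds, they also leave open how substituents on the new phenoxy ring would act on their own, since no single-place step yet starts from compound 4.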